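The compounds below may be only part of what the source reports. "The series", "measured", "known", "first", "only" and "open" are said of these compounds alone.

Three compounds share a core built around a central ring carrying a sulfonyl-linked aromatic group, and all were tested in an ADME assay on L02 cells (Homo sapiens) for cytotoxicity, read by MTT assay, with a stated time of 24 h; on this read-out higher numbers stand for weaker inhibition and lower numbers for stronger inhibition. Compound 1, `O=C1/C(=C/c2ccccc2F)CN(S(=O)(=O)c2ccc(C(F)(F)F)cc2)C/C1=C\c1ccccc1F`, gives 16200 nM in this assay. Compound 2, `O=C1/C(=C/c2ccccc2F)CN(S(=O)(=O)c2ccc(F)cc2)C/C1=C\c1ccccc1F`, gives 17500 nM. The change from compound 1 to compound 2 is fluoro in place of trifluoromethyl on an aromatic carbon, and that change made a 1.1-fold higher number from compound 1 to compound 2 (0.03 log units; within the scatter). Compound 3, `O=C1/C(=C/c2ccc(F)cc2)CN(S(=O)(=O)c2ccc(C(F)(F)F)cc2)C/C1=C\c1ccc(F)cc1`, gives 13500 nM in this assay, and its difference from compound 1 is not broken down here: the two have the same atoms joined differently, and the gap between their values lies within the scatter.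

Compound 4, `O=C1/C(=C/c2ccc(F)cc2)CN(S(=O)(=O)c2ccc(F)cc2)C/C1=C\c1ccc(F)cc1`, has not yet been measured. It differs from compound 3 by fluoro in place of trifluoromethyl on an aromatic carbon, the same change that leads from compound 1 to compound 2, at the same kind of place. Because that earlier change made a 1.1-fold higher number from compound 1 to compound 2 (0.03 log units; within the scatter), the step from compound 3 to compound 4 is expected to be small, about a 1.1-fold higher number from compound 3 to compound 4 (0.03 log units; within the scatter). Compound 4 is therefore estimated to give 14500 nM in this assay, likely between 8000 nM and 27000 nM.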

Compound 4, half-maximal inhibitory concentration: 14800 nM
For compound 4 the middle estimate is 1.0-fold (0.01 log units) below the measured one; measured number inside the range.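

In this assay, replacing 4-(trifluoromethyl)phenyl with 4-fluorophenyl gives a 1.1-fold higher number from compound 3 to compound 4 (0.04 log units; within the scatter), so the step is again too small to tell apart from repeat-measurement noise. Among these compounds, the swap therefore looks the same on the core of compound 1 and on the core of compound 3, which is what carrying a change across cores would ideally show: the same change on two cores in this assay, a 1.1-fold higher number (0.03 log units; within the scatter) from compound 1 to compound 2 and a 1.1-fold higher number (0.04 log units; within the scatter) from compound 3 to compound 4, 1.0-fold (0.01 log units) apart, within the scatter of two such steps This agreement rests on only two small steps on two cores made of the same atoms joined differently, so it does not show that the swap would stay this quiet on a more distant core or in another kind of test.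

The compounds shown carry only trifluoromethyl or fluoro at this spot, so it remains open whether an amine, a carboxylic acid or a longer alkyl chain there would shift the number. The fluoro groups on the other two aromatic rings also appear in only two arrangements, leaving open what a different group on those rings would do.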